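A Second Chloro Group on the Shared Core

This account rests on a few compounds, and the source may have more. Where it says the series, first, only, none or still open, it means among the compounds named here.

Compound 1 `ClCc1ccc(Cn2cnc3c(Cl)ncnc32)cc1` gives 9450 nM in a functional assay on UACC-62 cells (Homo sapiens) for cytotoxicity, read by sulforhodamine B assay, with a stated time of 48 h; a higher number here means that more compound is tolerated, a lower number that less compound is tolerated.
Compound 2 `ClCc1cccc(Cn2cnc3c(Cl)nc(Cl)nc32)c1` gives 6450 nM in this assay.

On these two numbers, compound 1 and compound 2 lie within the usual scatter of each other, so neither stands apart. Compound 3 `ClCc1ccc(Cn2cnc3c(Cl)nc(Cl)nc32)cc1` has not been measured yet. It differs from compound 1 in one place: chloro in place of hydrogen on an aromatic carbon. Compound 2 already carries this second chloro group and gives 6450 nM, close to compound 1, so a large change is not expected. The expected step is small, a 1.4-fold lower number from compound 1 to compound 3 (0.13 log units; within the scatter), toward a somewhat lower number but within the scatter. Compound 3 is estimated at 7000 nM, in a range from 3500 nM to 14000 nM.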

Compound 3, concentration lethal to 50% of the cells: 9330 nM
The estimate for compound 3 lay 1.3-fold (0.12 log units) below the measured number; the measured number falls inside the stated range.
By their numbers in this assay, from the lowest: compounds 2, 3 and 1 (each within the scatter of the next).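

Chloro in place of hydrogen on the aromatic carbon between two ring nitrogen atoms now has a direct one-place comparison: in this assay, the change gives a 1.0-fold lower number from compound 1 to compound 3 (0.01 log units; within the scatter), a step that compound 2 alone could not show. This carbon therefore takes a second chloro group with no difference beyond the scatter when the rest of compound 1 is kept unchanged. No measurement here bears on the reason for this result. Still open, as far as these compounds go, is whether an amine or a methoxy group on this same carbon would also stay within the scatter of compound 1.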